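Swapping the sulfonyl cap for a benzoyl cap

The source may hold more compounds than are shown below. What is called first, only, known or untested is meant among the compounds shown, and "the series" means these compounds.

Compound 1 `O=C1COCCN1c1ccc(/N=C\c2c[nH]c3ccccc23)cc1`: 90.8%
Compound 2 `Cc1ccc(S(=O)(=O)n2cc(/C=N\c3ccc(N4CCOCC4=O)cc3)c3ccccc32)cc1`: 56%

In an ADME assay on BV-2 cells (Mus musculus) for cytotoxicity, read by MTT assay, with a stated time of 48 h, tested at 60 uM (a higher number here means a weaker effect of the compound at the concentration tested, a lower number a stronger effect), compound 1 gives 90.8% and compound 2 gives 56%, so compound 2 stands at the lower of the two numbers, below compound 1 beyond the scatter. Among the measured compounds shown here, the one measured step, a number 34.8 percentage points lower from compound 1 to compound 2 (beyond the scatter), shows that placing a large group on the aromatic nitrogen of the shared core moved the number down sharply.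

Compound 3 `O=C1COCCN1c1ccc(/N=C\c2cn(C(=O)c3ccccc3)c3ccccc23)cc1` is not yet measured. It differs from compound 2 by benzoyl in place of (4-methylphenyl)sulfonyl on an aromatic nitrogen. For the measured compounds named here, both groups are large caps on the same aromatic nitrogen, so the step from compound 1 to compound 2 is the only guide; it suggests that compound 3 should sit closer to compound 2 than to compound 1. The expected step of a number 6 percentage points higher from compound 2 to compound 3 (within the scatter) is therefore small, within the scatter. Compound 3 is estimated at 62%, with a range from 40% to 85%.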

Compound 3, a percentage reported as activity, at one concentration (the size of the read-out at that concentration, not a potency): 57.5%
Compound 3: middle estimate off by 4.5 percentage points, on the high side; the range from low to high includes it.
By their numbers in this assay, from the lowest: compounds 2 and 3 (each within the scatter of the next); then compound 1.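

In this assay, changing the cap on the aromatic nitrogen from (4-methylphenyl)sulfonyl to benzoyl gives a number 1.5 percentage points higher from compound 2 to compound 3 (within the scatter) and so does not separate the two caps. Against the uncapped compound, benzoyl gives a number 33.3 percentage points lower from compound 1 to compound 3 (beyond the scatter) in a step of about the same size as the one seen with the sulfonyl cap, so the sharp fall is not confined to that one group and appears with both large caps tested on this nitrogen. Nothing available here explains why either cap has this effect.

The compounds shown leave open how small a cap can be and still produce the fall, for example a methyl or acetyl group on the same nitrogen. They also leave open whether a cap carrying an amine or a carboxylic acid would behave like benzoyl and (4-methylphenyl)sulfonyl.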